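The source may report more compounds than this note shows. Statements on the series, on what has been measured and on what is new or still open speak of the compounds shown alone.

The measured compounds:

Compound 1, `Cc1noc(NS(=O)(=O)c2cccc3cc(N(C)C)ccc23)c1C`, gave 840 nM in an assay on thoracic aorta for binding affinity to Endothelin-1 receptor (Rattus norvegicus); a higher number here means a weaker inhibitor, a lower number a stronger inhibitor.
Compound 2, `CC(=O)Nc1ccc2c(S(=O)(=O)Nc3onc(C)c3C)cccc2c1`, gave 1300 nM in this assay.
Compound 3, `Cc1noc(NS(=O)(=O)c2cccc3ccc(N(C)C)cc23)c1C`, gave 5600 nM in this assay.

Compound 1 and compound 3 are built from the same atoms joined differently; the difference between the two cores is not broken down here. What the two values show is that compound 3 gives the highest number of the three, and its distance from compound 1 and from compound 2 is in both cases beyond the usual scatter.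

Compound 2 arises from compound 1 by a single change, (acetamido in place of dimethylamino on an aromatic carbon). The step of a 1.5-fold higher number from compound 1 to compound 2 (0.19 log units; within the scatter) is within the scatter, so the two values are read as essentially alike.

Compound 4, `CC(=O)Nc1ccc2cccc(S(=O)(=O)Nc3onc(C)c3C)c2c1`, has not yet been measured in this assay. It differs from compound 3 by acetamido in place of dimethylamino on an aromatic carbon, which is the same change as that from compound 1 to compound 2, made at the same kind of position on the core of compound 3.

The expectation for compound 4 rests on one measured step only, and that step was made on the core of compound 1. Compound 4 is expected to sit near compound 3 because a 1.5-fold higher number from compound 1 to compound 2 (0.19 log units; within the scatter) was within the scatter, with an estimated step of a 1.3-fold higher number from compound 3 to compound 4 (0.10 log units; within the scatter). The estimate for compound 4 in this assay is therefore 7000 nM, expected to fall between 3000 nM and 16000 nM.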

Compound 4, half-maximal inhibitory concentration: 870 nM
Estimate against measurement, compound 4: 8.0-fold (0.91 log units) above, outside the stated range (below it).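

In this assay, putting acetamido in place of dimethylamino on an aromatic carbon gave a 6.4-fold lower number from compound 3 to compound 4 (0.81 log units; beyond the scatter), and this step does not match the one seen for the same change on the other core: the same change on two cores in this assay, a 1.5-fold higher number (0.19 log units; within the scatter) from compound 1 to compound 2 and a 6.4-fold lower number (0.81 log units; beyond the scatter) from compound 3 to compound 4, 10-fold (1.00 log units) apart, beyond the scatter of two such steps

Within this series, then, the result of this change on the core of compound 1 did not carry over to the core of compound 3, and the reading of a single step on one core gave no safe guide to the other. What this does not show is why the two steps part, or how the change would behave on any further core, as the comparison rests on a single pair of steps and on two cores only.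

The compounds shown leave open how other groups on the same aromatic carbon would fare on these two cores, for instance a primary amine, a methoxy group or a longer acyl chain in place of the acetyl of acetamido. They also leave open whether such groups would show a similar gap between the two cores or would give steps that agree.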